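A few compounds are considered here, and "the series" means these few. Any claim that something is new, unique, unknown or untested is made for them only; others in the source may bear on it.

Compound 1 `COc1cc(-c2cc(/C=C/C(=O)c3ccc(N)cc3)[nH]n2)cc(OC)c1OC` was tested in a functional assay on UACC-257 cells (Homo sapiens) for cytotoxicity, read by sulforhodamine B assay, with a stated time of 48 h, tested at 1 uM (on this read-out higher numbers stand for a weaker effect at the one concentration tested and lower numbers for a stronger effect), where compound 1 gives 91%. Two companions were run alongside it. Compound 2 `COc1ccc(-c2cc(/C=C/C(=O)c3ccc(N)cc3)[nH]n2)cc1OC` gives 96% in this assay, and compound 3 `COc1ccc(-c2cc(/C=C/C(=O)c3cc(OC)c(OC)c(OC)c3)[nH]n2)cc1OC` gives 89%. Compound 1 therefore sits between its two companions on the numbers shown, closest to compound 3 and furthest from compound 2, yet both gaps are within the scatter, so the three numbers cannot be told apart. Among the measured compounds shown here, the only single-point step among them, a number 5 percentage points higher from compound 1 to compound 2 (within the scatter), is a change at the aryl group attached to the shared core, not at the carbonyl carbon.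

Compound 4 `COc1cc(-c2cc(/C=C/C(=O)c3ccc(F)c(F)c3)[nH]n2)cc(OC)c1OC` is not yet measured. It differs from compound 1 at the carbonyl carbon: 3,4-difluorophenyl in place of 4-aminophenyl on a carbonyl carbon. For the measured compounds named here, no measured step touches that position with one change alone; compound 3 carries a different group on the carbonyl carbon than compound 1 but also differs elsewhere, and its value lies within the scatter of that of compound 1. On this basis the expected step of a number 1 percentage points lower from compound 1 to compound 4 (within the scatter) in this assay is none beyond the scatter. The estimate for compound 4 in this assay is 90%, ranging from 76% to 102%.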

Compound 4, a percentage reported as activity, at one concentration (the size of the read-out at that concentration, not a potency): 72%
Compound 4: the middle estimate sits 18 percentage points above what was measured; the whole stated range lies above it.
By their numbers in this assay, from the lowest: compound 4; then compounds 3, 1 and 2 (each within the scatter of the next).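

In this assay, among the compounds shown here, the carbonyl carbon is the first position where one change alone moves the read-out beyond the scatter: 3,4-difluorophenyl in place of 4-aminophenyl gives a number 19 percentage points lower from compound 1 to compound 4 (beyond the scatter) and so a modestly stronger effect at the one concentration tested. The only earlier single change, at the aryl group attached to the shared core, gave a number 5 percentage points higher from compound 1 to compound 2 (within the scatter) and so showed no effect that could be told apart, which makes this the first sign that the read-out responds to a change among these compounds. The exchange removes a hydrogen-bond donor and acceptor and brings in two fluorines, but no measurement bears on why the read-out moved.

The compounds shown leave open whether the step comes from losing the amine or from gaining the fluorines, which a plain phenyl or a phenyl carrying a single fluorine or a chlorine on the carbonyl carbon would help to separate. They also leave open whether 3,4-difluorophenyl gives a similar step when the core carries the aryl group of compound 2.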